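Chain Lengthening on a Shared Core: Cytotoxicity Notes

This account rests on a few compounds, and the source may have more. Where it says the series, first, only, none or still open, it means among the compounds named here.

Compound 1 `CCCCCCC(=O)NCC(C)(C)CC1=C(O)C(=O)c2ccccc2C1=O` and compound 2 `CCCCCCCCC(=O)NCC(C)(C)CC1=C(O)C(=O)c2ccccc2C1=O` share one core and differ only in chain length. In an ADME assay on Vero cells (Chlorocebus sabaeus) for cytotoxicity, read by reporter gene assay, with a stated time of 4 days (on this read-out higher numbers stand for weaker inhibition and lower numbers for stronger inhibition), compound 1 gives 24800 nM, and compound 2 gives 16700 nM. The change between them, (ethyl in place of hydrogen on a saturated chain carbon, six bonds along the chain from a carbonyl carbon), produced a 1.5-fold lower number from compound 1 to compound 2 (0.17 log units; within the scatter), so these two values show no separation. Compound 3 `CCCCCCCCCCCCCCCC(=O)OCC(C)(C)CC1=C(O)C(=O)c2ccccc2C1=O` carries a longer chain on a different core; the difference between the two cores is not broken down here. In this assay compound 3 gives 4410 nM, the lowest of the three numbers and beyond the scatter from both compound 1 and compound 2. Compound 4 `CCCCCCCCCCCCCCCCCC(=O)OCC(C)(C)CC1=C(O)C(=O)c2ccccc2C1=O` is not yet measured. It differs from compound 3 by ethyl in place of hydrogen on a saturated chain carbon, ten or more bonds along the chain from a carbonyl carbon, the same kind of change as that from compound 1 to compound 2, though at a different place along the chain. For compound 4 the expected step is a 1.3-fold lower number from compound 3 to compound 4 (0.10 log units; within the scatter), small because the step already measured was a 1.5-fold lower number from compound 1 to compound 2 (0.17 log units; within the scatter). Compound 4 is therefore estimated at 3500 nM, with a likely range from 1500 nM to 9000 nM.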

Compound 4, half-maximal inhibitory concentration: 15500 nM
Compound 4: the middle estimate sits 4.4-fold (0.65 log units) below what was measured; measured number outside the range, above it.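

On the core of compound 3, ethyl in place of hydrogen on a saturated chain carbon, ten or more bonds along the chain from a carbonyl carbon, gives a 3.5-fold higher number from compound 3 to compound 4 (0.55 log units; beyond the scatter) in this assay. Set beside the earlier step, this change does not carry from one core to the other as a fixed step: the same change on two cores in this assay, a 1.5-fold lower number (0.17 log units; within the scatter) from compound 1 to compound 2 and a 3.5-fold higher number (0.55 log units; beyond the scatter) from compound 3 to compound 4, 5.2-fold (0.72 log units) apart, beyond the scatter of two such steps. The comparison rests on one pair per core, and the two pairs also differ in the place of the change along the chain, so it does not show whether the core or that place separates the two steps, nor how the change would read on any further core.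

Open, as far as these compounds go, is how a longer chain on the core of compound 1 would read in this assay, and whether a shorter chain on the core of compound 3 would read closer to compound 3 or compound 4. Also open, from the compounds shown here alone, is how a chain ending in an amine or a carboxylic acid would read on either core.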